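The compounds below may be only part of what the source reports. "The series", "measured", "known", "first", "only" and "open" are said of these compounds alone.

Measured compounds:
compound 1, `Cc1ccccc1OCCCCCn1ccc(=O)[nH]c1=O`, > 100000 nM
compound 2, `CCCOC(=O)c1ccc(OCCCCCn2ccc(=O)[nH]c2=O)cc1`, > 100000 nM
compound 3, `O=c1ccn(CCCCCOc2ccc(Cl)cc2)c(=O)[nH]1`, "not determined" (no result reported)

The study reports an ADME assay on HEL cells (Homo sapiens) for cytotoxicity (on this read-out lower numbers stand for higher toxicity in this test and higher numbers for lower toxicity in this test), for a small set of compounds that share one core. In this assay compound 1 gives > 100000 nM, which is a limit of the assay and not a number. Compound 2 gives > 100000 nM in this assay, again a limit rather than a number. Among the compounds with values here, for compound 3 this assay gives "not determined" (no result reported), so compound 3 has no single number of its own; what surrounds it is the limit of > 100000 nM in this assay, at which 2 of the 3 values shown sit, and no measured pair of compounds differing in one place is available to fix the size of any step.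

The compound still to be measured is compound 4, `O=c1ccn(CCCCCOc2ccccc2)c(=O)[nH]1`. The change from compound 3 to compound 4 is hydrogen in place of chloro on an aromatic carbon. Within the data shown here, since no measured step in this assay exists for comparison, the expectation rests only on the two limits already seen, and a step in this assay of no size beyond the usual scatter is expected in either direction. On that basis compound 4 is estimated to give 100000 nM in this assay, within a range from 30000 nM to 300000 nM, most likely again as a limit.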

Compound 4, half-maximal cytotoxic concentration: > 100000 nM
Compound 4: no number, only a limit (the forecaster's own chance of this, stated with the estimate: 75%); the middle value lies on the limit itself.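

In this assay compound 4 gives > 100000 nM, a limit of the assay and not a number. The steps from compound 1 and from compound 2 to compound 4 cannot be read; all three values are limits. The compounds shown leave open at what concentration any of them becomes toxic to these cells, and whether 4-chlorophenyl in place of phenyl changes the read-out at all.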